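The compounds below may be only part of what the source reports. "The series", "measured", "known", "first", "only" and "open" are said of these compounds alone.

Compound 1 `COc1ccc(OC)c(/C=C/C(=O)N/N=C/c2ccccc2)c1`: "not determined" (no result reported)
Compound 2 `COc1ccc(OC)c(/C=C/c2nnc(Nc3ccc(Cl)cc3)o2)c1`: > 100000 nM

Compound 1 has no reported result in a functional assay on SR cells (Homo sapiens) for antiproliferative activity, read by sulforhodamine B assay, with a stated time of 48 h; a higher number here means a weaker inhibitor of growth, a lower number a stronger inhibitor of growth; its entry reads "not determined" (no result reported), so it stands on no number at all. For compound 2 the entry in this assay is a limit of the assay rather than a number, > 100000 nM. For the measured compounds named here, of the two values shown, one is the limit of > 100000 nM in this assay, at which 1 of the 2 values shown sits, and no numerical step can be drawn between the two measured compounds.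

Compound 3 `COc1ccc(OC)c(/C=C/C(=O)N/N=C/c2ccc(Cl)cc2)c1` differs from compound 1 by chloro in place of hydrogen on an aromatic carbon. Going by the values given here, no measured step covers this change, and with no number for compound 1 no size or direction of the step in this assay can be read; nothing beyond the usual scatter is assumed for it. Compound 3 is therefore estimated to give about 30000 nM in this assay, within a range of 3000 nM to 100000 nM.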

Compound 3, concentration for total growth inhibition: 16400 nM
Estimate against measurement, compound 3: 1.8-fold (0.26 log units) above; measured number inside the range.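

For the compounds shown here, with no number for compound 1 in this assay, the result for compound 3 yields no step between the two. The compounds shown leave open whether going from phenyl to 4-chlorophenyl changes growth inhibition in this assay, and if so, in which direction and by how much.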